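A Methyl Group Added to Compound 2: Expected Effect

A few compounds are considered here, and "the series" means these few. Any claim that something is new, unique, unknown or untested is made for them only; others in the source may bear on it.

Of the compounds shown here, two have been measured in a functional assay on the whole organism (strain Albino) for inhibition, with Rattus norvegicus as the target, with stated times of 1 h and 24 h, at a dose of 20 mg/kg by the oral route; on this read-out lower numbers stand for less inhibition and higher numbers for more inhibition at the one dose given (going by the name of the read-out). Compound 1 `O=C(O)CCC1=C(c2ccccc2)NC(=S)NC1c1ccccc1O` gives 2.15% in this assay, and compound 2 `O=C(O)CCC1=C(c2ccccc2)NC(=S)NC1c1ccco1` gives 16.5%. Going by the values given here, the only step known so far runs a number 14.4 percentage points higher from compound 1 to compound 2 (beyond the scatter), so compound 2 stands highest of the two numbers, with compound 1 below it beyond the scatter.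

Compound 3 `Cc1ccc(C2=C(CCC(=O)O)C(c3ccco3)NC(=S)N2)cc1` differs from compound 2 by methyl in place of hydrogen on an aromatic carbon. Among the compounds with values here, this change sits on the six-membered aromatic ring of carbon only, whereas the one measured step concerns the group on the saturated ring carbon; no measured step therefore bears on the present change, and nothing in the numbers points in either direction. The expectation is no step beyond the scatter in this assay. Compound 3 is estimated at 17%, expected to lie between 4% and 32%. The expected step is then a number 0.5 percentage points higher from compound 2 to compound 3 (within the scatter), within the scatter.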

Compound 3, a percentage reported as inhibition, in the whole organism at one dose (the size of the read-out at that dose, not a potency): 14.4%
For compound 3 the middle estimate is 2.6 percentage points above the measured one; low and high end bracket the measured number.
By their numbers in this assay, from the lowest: compound 1; then compounds 3 and 2 (each within the scatter of the next).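

In this assay, going by these compounds alone, this is the first look at the six-membered aromatic ring of carbon only, and the step is a number 2.1 percentage points lower from compound 2 to compound 3 (within the scatter). The two compounds therefore cannot be told apart in this read-out, so a single added carbon at this place, para to a large group, costs nothing that can be separated from ordinary scatter. Unlike the earlier step, which concerned the group on the saturated ring carbon, this result shows that phenyl to 4-methylphenyl can be made with the furan-2-yl group in place and with no clear effect at this one dose, although no supporting measurement offers an explanation.

One methyl says little about the limits of this place. An amine, a methoxy group or a longer chain such as propyl could give a quite different number here.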